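A few compounds are considered here, and "the series" means these few. Any claim that something is new, unique, unknown or untested is made for them only; others in the source may bear on it.

Measured in a functional assay on CCRF-CEM cells (Homo sapiens) for antiproliferative activity, read by trypan blue exclusion, with a stated time of 72 h; on this read-out lower numbers stand for stronger inhibition and higher numbers for weaker inhibition:
- Compound 1 `NC(=O)NC(=O)c1cc(NC(=O)CBr)ccc1F`: < 10 nM (a limit)
- Compound 2 `Cc1ccc(NC(=O)CI)cc1C(=O)NC(N)=O`: 20000 nM

Only two results are available so far. Compound 1 gives < 10 nM, which is a limit of the assay and not a number. In this assay, going by the values given here, compound 2 gives 20000 nM, the only actual number so far, and it stands at the weak end of what has been seen.

Among the compounds with values here, no measured pair differs in just one place, so no single change has yet been measured on its own. Compound 3 `NC(=O)NC(=O)c1cc(NC(=O)CI)ccc1F` is reached from compound 2 by putting fluoro in place of methyl on an aromatic carbon, ortho to the carbamoylcarbamoyl group and para to the ((iodomethyl)carbonyl)amino group: fluoro in place of methyl on an aromatic carbon.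

A large step toward stronger inhibition is expected in this assay. This expectation rests on compound 1, which carries the same fluoro and gives < 10 nM, a limit. Compound 1 lacks the ((iodomethyl)carbonyl)amino group, so the expected range stays wide. The expected change is a 670-fold lower number from compound 2 to compound 3 (2.82 log units; beyond the scatter). For compound 3 the estimated value is 30 nM, with an expected range of 3 nM to 2000 nM.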

Compound 3, half-maximal inhibitory concentration: < 10 nM
Compound 3 was reported as a limit (the forecaster's own chance of this, stated with the estimate: 35%); middle value at least 3.0-fold (0.47 log units) from the limit.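

In this assay compound 3 gives < 10 nM, which is a limit of the assay and not a number. Going by these compounds alone, putting fluoro in place of methyl on the aromatic carbon, ortho to the carbamoylcarbamoyl group and para to the ((iodomethyl)carbonyl)amino group, gives an at least 2000-fold lower number from compound 2 to compound 3 (3.30 log units; beyond the scatter), the first change in this set to be measured on its own. Compound 1 differed from compound 2 in more than one place and could not separate this position from the halogen on the chain, whereas here the ((iodomethyl)carbonyl)amino group stays the same and the large step belongs to this position alone.

Within the data shown here, whether a hydrogen, a chloro or a methoxy at this position would sit near fluoro or near methyl remains open, so the step describes only this one exchange. The comparison of bromo with iodo on the chain cannot be read, and the full size of the step from methyl to fluoro also stays open, because the results at the strong end are limits: the limit of < 10 nM in this assay, at which 2 of the 3 values shown sit.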